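A side group swap on compound 2

The compounds below may be only part of what the source reports. "The series", "measured", "known", "first", "only" and "open" are said of these compounds alone.

Compound 1 `O=C(N[C@H]1CN(S(=O)(=O)c2ccccc2)C[C@@H]1C(=O)N[C@H]1CCCNC1)c1cc(-c2ccccc2)on1`: 94000 nM
Compound 2 `O=C(N[C@H]1CN(S(=O)(=O)c2ccccc2)C[C@@H]1C(=O)N1C[C@H]2CCNC[C@H]21)c1cc(-c2ccccc2Cl)on1`: 265000 nM

In a physicochemical assay for solubility, at pH 7.4 (on this read-out higher numbers stand for higher solubility and lower numbers for lower solubility), compound 2 stands highest of the two, with 265000 nM, beyond the usual scatter from compound 1. Compound 3 `CN1CCC[C@H](NC(=O)[C@H]2CN(S(=O)(=O)c3ccccc3)C[C@@H]2NC(=O)c2cc(-c3ccccc3Cl)on2)C1` differs from compound 2 in one place, on a carbonyl carbon: a group of 8 heavy atoms (6 carbon, 2 nitrogen; one six-membered non-aromatic ring with 1 hetero atom) in place of a group of 8 heavy atoms (6 carbon, 2 nitrogen; one four-membered non-aromatic ring with 1 hetero atom, one six-membered non-aromatic ring with 1 hetero atom), on a carbonyl carbon. Within the data shown here, no measured pair shows a change of this kind, so the expectation rests on the two values alone. Compound 2 gives 265000 nM, the top of the range seen so far, and compound 1 gives 94000 nM, so a number between them seems most likely. The expected step is downward and modest, a 1.9-fold lower number from compound 2 to compound 3 (0.28 log units; within the scatter). The estimate for compound 3 is 140000 nM, with a range of 50000 nM to 330000 nM.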

Compound 3, solubility: 503000 nM
Compound 3: the middle estimate sits 3.6-fold (0.56 log units) below what was measured, and the stated range ends below it.
By their numbers in this assay, from the lowest: compound 1; then compounds 2 and 3 (each within the scatter of the next).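

On this carbonyl carbon, replacing the group with a four-membered and a six-membered ring by (1-methylpiperidin-3-yl)amino gives a 1.9-fold higher number from compound 2 to compound 3 (0.28 log units; within the scatter) in this assay. This step lies within the scatter, so this assay does not separate the two groups, although the four-membered ring is gone and one defined stereocentre fewer remains in the group. No measurement shown here offers an explanation for the result. Still open, from the compounds shown here alone, is whether this tolerance extends to other kinds of group on this carbonyl carbon, such as an open-chain dimethylamino group or a carboxylic acid.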